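From Chloro to Methyl: Expected Cytotoxicity of Compound 4

The compounds below may be only part of what the source reports. "The series", "measured", "known", "first", "only" and "open" are said of these compounds alone.

Compound 1 `Clc1ccc2c(NCCNc3nccc(Nc4ccc(Br)cc4)n3)ccnc2c1`: "not active" (no number reported)
Compound 2 `Clc1ccc2c(NCCCNc3nccc(Nc4ccccc4)n3)ccnc2c1`: 12800 nM
Compound 3 `Clc1ccc(Nc2ccnc(NCCCNc3ccnc4cc(Cl)ccc34)n2)cc1`: 13400 nM

In an ADME assay on Vero cells (Chlorocebus sabaeus) for cytotoxicity, read by neutral red uptake, with a stated time of 72 h (on this read-out higher numbers stand for weaker inhibition and lower numbers for stronger inhibition), compound 2 gives 12800 nM and compound 3 gives 13400 nM. Compound 1 was reported only as "not active" (no number reported), without a number. Compound 3 holds the higher of the two numbers, yet its gap to compound 2 lies within the scatter, so no order can be claimed. Compound 4 `Cc1ccc(Nc2ccnc(NCCCNc3ccnc4cc(Cl)ccc34)n2)cc1` differs from compound 3 by methyl in place of chloro on an aromatic carbon. For the measured compounds named here, the single measured step, a 1.0-fold higher number from compound 2 to compound 3 (0.02 log units; within the scatter), placed a chloro on an aromatic carbon and stayed within the scatter; no exchange of chloro for methyl has been measured. The expectation is therefore a step of a 1.0-fold lower number from compound 3 to compound 4 (0.01 log units; within the scatter), not beyond the scatter. Compound 4 is estimated at 13000 nM in this assay, ranging from 6000 nM to 28000 nM.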

Compound 4, half-maximal inhibitory concentration: 18500 nM
Estimate against measurement, compound 4: 1.4-fold (0.15 log units) below; the measured number falls inside the stated range.
By their numbers in this assay, from the lowest: compounds 2, 3 and 4 (each within the scatter of the next).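

With methyl, the position on the aromatic carbon para to a large group has now carried hydrogen, chloro and methyl, and in this assay the readings stay within the scatter: a 1.4-fold higher number from compound 3 to compound 4 (0.14 log units; within the scatter) and a 1.4-fold higher number from compound 2 to compound 4 (0.16 log units; within the scatter). For the compounds shown here, the exchange of chloro for methyl, seen here for the first time, thus leaves the reading as unresolved as the earlier chloro step did. Nothing measured here bears on these readings. Going by these compounds, whether an amine or a carboxylic acid at this position would also stay within the scatter remains open. So does the reading with a longer chain in the linker.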